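This account rests on a few compounds, and the source may have more. Where it says the series, first, only, none or still open, it means among the compounds named here.

Measured so far in a functional assay on A549 cells (Homo sapiens) for cytotoxicity, read by MTT assay, with a stated time of 24 h; on this read-out higher numbers stand for weaker inhibition and lower numbers for stronger inhibition:
Compound 1, `C=CC1=C(C(=O)NCc2ccc(C)cc2)C(c2ccc(OC)cc2)OC1`. Its result is a limit of the assay, > 100000 nM.
Compound 2, `C=CC1=C(C(=O)Nc2ccc(OCC)cc2)C(c2ccc(F)cc2)OC1`. Its result is reported as "not active" (no number reported), without a number.
Compound 3, `C=CC1=C(C(=O)NCc2ccc(C)cc2)C(c2ccc(OC)c(OC)c2)OC1`. Its result is also a limit of the assay, > 100000 nM.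

Compound 3 therefore stands only at a limit, namely (the limit of > 100000 nM in this assay, at which 2 of the 3 values shown sit), and the step that the two limits leave unreadable from compound 1 to compound 3 cannot be read. Compound 4, `C=CC1=C(C(=O)Nc2ccccc2)C(c2ccc(OC)c(OC)c2)OC1`, differs from compound 3 by phenyl in place of 4-methylbenzyl on an amide-type nitrogen. Going by the values given here, none of the measured steps covers this change, so there is no measured basis for a shift in either direction. Compound 4 is expected to remain at the limit, with a number no higher from compound 3 to compound 4 (the limit leaves the size open) amounting to no readable step. For compound 4 the estimate is 100000 nM, between 30000 nM and 300000 nM.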

Compound 4, half-maximal inhibitory concentration: > 100000 nM
Compound 4: a limit, no number; the forecaster's own chance of this, stated with the estimate: 75%; the middle value sits exactly at the limit.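

Compound 3 and compound 4 both sit at a limit of the assay, so no step can be read between them: the limit of > 100000 nM in this assay, at which 3 of the 4 values shown sit.

The compounds shown leave open whether phenyl in place of 4-methylbenzyl on an amide-type nitrogen changes cytotoxicity at all.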